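Methyl to Trifluoromethyl on the Outer Urea Ring

The compounds below may be only part of what the source reports. "The series", "measured", "known", "first", "only" and "open" are said of these compounds alone.

Two compounds have been measured in a functional assay on MDA-MB-231 cells (Homo sapiens) for inhibition, read by sulforhodamine B assay, with a stated time of 48 h, tested at 10 uM; on this read-out lower numbers stand for a stronger effect and higher numbers for a weaker effect at the one concentration tested:

Compound 1, `COc1cc2cc(Oc3ccc(NC(=O)Nc4ccccc4)cc3)c(C)nc2cc1OC`, gives 80%.
Compound 2, `COc1cc2cc(Oc3ccc(NC(=O)Nc4ccc(C)cc4)cc3)c(C)nc2cc1OC`, gives 85.6%.

Within the data shown here, both numbers are high, so at the single concentration tested neither compound holds back cell growth strongly. Among the measured compounds shown here, compound 2 stands as the higher of the two numbers, but the only measured step, a number 5.6 percentage points higher from compound 1 to compound 2 (within the scatter), is within the scatter, so the two compounds cannot be told apart on this read-out.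

Compound 3, `COc1cc2cc(Oc3ccc(NC(=O)Nc4ccc(C(F)(F)F)cc4)cc3)c(C)nc2cc1OC`, has not yet been measured. It differs from compound 2 by trifluoromethyl in place of methyl on an aromatic carbon. For the measured compounds named here, no measured step exchanges one carbon-bearing group for another; the one step available, a number 5.6 percentage points higher from compound 1 to compound 2 (within the scatter), altered the same aromatic carbon and stayed within the scatter. On that basis no change beyond the scatter is expected from compound 2 to compound 3, an expected step of a number 3.6 percentage points lower from compound 2 to compound 3 (within the scatter). The estimate for compound 3 in this assay is 82%, with an expected range from 62% to 100%.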

Compound 3, a percentage reported as activity, at one concentration (the size of the read-out at that concentration, not a potency): 80.9%
The estimate for compound 3 lay 1.1 percentage points above the measured number; measured number inside the range.
By their numbers in this assay, from the lowest: compounds 1, 3 and 2 (each within the scatter of the next).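

In this assay, among these compounds, putting trifluoromethyl in place of methyl, para to a large group on the outer ring, comes to a number 4.7 percentage points lower from compound 2 to compound 3 (within the scatter) and is the first measured exchange of one carbon-bearing group for another at this position. The comparison with the unsubstituted ring gives a number 0.9 percentage points higher from compound 1 to compound 3 (within the scatter) for trifluoromethyl in place of hydrogen, so even a group of 4 heavy atoms, 3 of them fluorine, cannot be told apart from hydrogen on this read-out. Hydrogen, methyl and trifluoromethyl on this aromatic carbon therefore all give results within the scatter of one another, and no measurement is available that would say what lies behind this.

The compounds shown leave open whether a group of a different kind on this carbon, such as an amine, a carboxylic acid or a longer chain, would shift the number beyond the scatter. They also leave open whether methyl or trifluoromethyl would behave the same way on another carbon of the outer ring.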